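Phenyl exchanges on the shared core: compound 3 to compound 4

This account rests on a few compounds, and the source may have more. Where it says the series, first, only, none or still open, it means among the compounds named here.

In a functional assay on KB cells (Homo sapiens) for cytotoxicity (on this read-out lower numbers stand for an effect already at smaller amounts and higher numbers for an effect only at larger amounts of compound), compound 1 (`COC1=C(C)C(=O)/C(=C(O)/C=C/c2cccc(OC)c2)C(=O)C1(C)C`) reads 3.3 ug/mL and compound 2 (`COC1=C(C)C(=O)/C(=C(O)/C=C/c2ccccc2OC)C(=O)C1(C)C`) reads 3.3 ug/mL on the same shared core. Compound 3 (`COC1=C(C)C(=O)/C(=C(O)/C=C/c2ccc(F)cc2)C(=O)C1(C)C`) reads 3.7 ug/mL and stands within the scatter of both.

Next in the series is compound 4 (`COC1=C(C)C(=O)/C(=C(O)/C=C/c2c(C)cccc2C)C(=O)C1(C)C`), which has 2,6-dimethylphenyl in place of 4-fluorophenyl. The change is counted as 2,6-dimethylphenyl in place of 4-fluorophenyl on a double-bonded chain carbon bound to a double-bonded chain carbon and lies on a double-bonded chain carbon bound to a double-bonded chain carbon.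

Three measured exchanges at this same place bear on it. These are no change at the digits printed from compound 1 to compound 2 (within the scatter) and then a 1.1-fold higher number from compound 1 to compound 3 (0.05 log units; within the scatter) and finally a 1.1-fold higher number from compound 2 to compound 3 (0.05 log units; within the scatter) as the third. None of them leaves the scatter. Within the data shown here, no measured compound carries 2,6-dimethylphenyl, so this guidance is indirect and the range has to stay wide.

As a 1.1-fold higher number from compound 2 to compound 3 (0.05 log units; within the scatter) stays so small for compound 3, no step beyond the scatter is expected in this assay for the new exchange. The expected step is a 1.1-fold lower number from compound 3 to compound 4 (0.02 log units; within the scatter) and no clear direction is anticipated. Compound 4 is estimated at 3.5 ug/mL (expected range 1.7 ug/mL to 7.5 ug/mL) in this assay once measured.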

Compound 4, concentration for half-maximal effect: 7.1 ug/mL
Compound 4: the middle estimate sits 2.0-fold (0.31 log units) below what was measured; the measured number falls inside the stated range.
By their numbers in this assay, from the lowest: compounds 1, 2, 3 and 4 (each within the scatter of the next, the first and the last beyond it).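

Among these compounds, at this place, on a double-bonded chain carbon bound to a double-bonded chain carbon, the exchanges among the earlier phenyl groups all stayed within the scatter, whereas 2,6-dimethylphenyl yields the first steps beyond it in this assay: a 2.2-fold higher number from compound 2 to compound 4 (0.33 log units; beyond the scatter) and a 2.2-fold higher number from compound 1 to compound 4 (0.33 log units; beyond the scatter), both modest. The separation holds only against the 2-methoxyphenyl and 3-methoxyphenyl groups, since the exchange for 4-fluorophenyl remains within the scatter at a 1.9-fold higher number from compound 3 to compound 4 (0.28 log units; within the scatter), so the position tolerates all four phenyl groups within a narrow span of values and shows only a slight sensitivity to this change. No supporting data accompany these values that could account for the difference between the groups.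

The compounds shown do not separate the contribution of the two methyl groups, so a 2-methylphenyl or 4-methylphenyl group at the same place would be informative. Also open, going by these compounds, is whether a group of a different kind, such as an amine or a carboxylic acid on the phenyl ring, or a longer chain in place of the ring, would stay within this narrow span or move clearly away from it.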